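Swapping an ethylphenyl for a naphthyl on a shared core

The compounds below may be only part of what the source reports. "The series", "measured", "known", "first", "only" and "open" are said of these compounds alone.

Of the compounds shown here, two with the same core have been tested in a functional assay on M14 cells (Homo sapiens) for inhibition, read by sulforhodamine B assay, with a stated time of 48 h, tested at 10 uM; on this read-out lower numbers stand for less inhibition and higher numbers for more inhibition at the one concentration tested (going by the name of the read-out). Compound 1 `c1ccc(-c2cn3ccnc3c(-c3ccc4ncn(C5CCCCC5)c4c3)n2)cc1` gives 38.2%. Compound 2 `CCc1ccc(-c2cn3ccnc3c(-c3ccc4ncn(Cc5ccccc5)c4c3)n2)cc1` gives 36.4%, a number that sits within the usual scatter of the value for compound 1, so the two cannot be told apart. Compound 3 `c1ccc(Cn2cnc3ccc(-c4nc(-c5cccc6ccccc56)cn5ccnc45)cc32)cc1` is not yet measured. It differs from compound 2 in one place: naphthalen-1-yl in place of 4-ethylphenyl on an aromatic carbon. Among the measured compounds shown here, no measured pair shows what such a change does here, so no shift beyond the scatter is expected from compound 2 to compound 3 in this assay, giving a number 1.6 percentage points higher from compound 2 to compound 3 (within the scatter). Compound 3 is therefore estimated at 38%, most likely between 20% and 56%.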

Compound 3, a percentage reported as inhibition, at one concentration (the size of the read-out at that concentration, not a potency): 4.41%
Estimate against measurement, compound 3: 33.6 percentage points above, outside the stated range (below it).
By their numbers in this assay, from the lowest: compound 3; then compounds 2 and 1 (each within the scatter of the next).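

This position on the shared core is not indifferent to the group it carries: in this assay, naphthalen-1-yl in place of 4-ethylphenyl gives a number 32 percentage points lower from compound 2 to compound 3 (beyond the scatter) and leaves little inhibition at the one concentration tested. The swap adds a second six-membered aromatic ring of carbon and changes no hydrogen-bond donor or acceptor count. Nothing available explains why the inhibition falls.

Still open, from the compounds shown here alone, is whether naphthalen-2-yl or a phenyl ring carrying a methoxy group would keep the inhibition of compound 2. A single step also cannot show whether the same swap would act alike on other compounds.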